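The source may hold more compounds than are shown below. What is called first, only, known or untested is meant among the compounds shown, and "the series" means these compounds.

In an ADME assay on J774.A1 cells (Mus musculus) for cytotoxicity, read by MTT assay, with a stated time of 72 h (on this read-out higher numbers stand for lower toxicity in this test and lower numbers for higher toxicity in this test), compound 2 `COc1cccc(-c2cc(-c3ccc(C4NC(=O)c5ccccc5N4)cc3)nc(N)n2)c1OC` gives > 400000 nM, which is a limit of the assay and not a number. It stands at the limit of > 400000 nM in this assay, at which 1 of the 3 values shown sits. Compound 1 `COc1ccc(-c2cc(-c3ccc(C4NC(=O)c5ccccc5N4)cc3)nc(N)n2)cc1` gives 178000 nM, while compound 3 `CCCCNC(c1ccc(C2NC(=O)c3ccccc3N2)cc1)c1nnnn1C(C)(C)C` comes with "not determined" (no result reported) and offers no guide. Compound 4 `COc1cc(-c2cc(-c3ccc(C4NC(=O)c5ccccc5N4)cc3)nc(N)n2)cc(OC)c1OC` keeps the core of compound 2 and exchanges one group: 3,4,5-trimethoxyphenyl in place of 2,3-dimethoxyphenyl on an aromatic carbon. Here 3,4,5-trimethoxyphenyl takes the place of 2,3-dimethoxyphenyl on an aromatic carbon. Going by the values given here, only one measured step bears on this exchange: an at least 2.2-fold higher number from compound 1 to compound 2 (0.35 log units; beyond the scatter). Going by these compounds, that step is itself known only through a limit, so its full size remains open. With compound 2 at the limit, a measured number for compound 4 could only lie lower in this assay. Compound 1 at 178000 nM shows that such lower numbers occur with this core. A modest step toward a lower number is therefore expected, though compound 4 may also stop at the limit. The expected change is an at least 1.4-fold lower number from compound 2 to compound 4 (0.15 log units; that floor lies within the scatter). Compound 4 is estimated at 280000 nM, with an expected range of 110000 nM to 600000 nM.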

Compound 4, half-maximal cytotoxic concentration: 103000 nM
Estimate against measurement, compound 4: 2.7-fold (0.43 log units) above; measured number outside the range, below it.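

In this assay, the exchange at this position on the shared core gives an at least 3.8-fold lower number from compound 2 to compound 4 (0.58 log units; beyond the scatter), so a 3,4,5-trimethoxyphenyl group here goes with a clearly lower number than the 2,3-dimethoxyphenyl group. The value of compound 2 is a limit of the assay and not a number, so this step gives only a floor for the size of the change: the limit of > 400000 nM in this assay, at which 1 of the 4 values shown sits. Against the 4-methoxyphenyl group the exchange gives a 1.7-fold lower number from compound 1 to compound 4 (0.24 log units; within the scatter), so compound 4 cannot be told apart from compound 1, and the number does not simply follow the addition of methoxy groups.

Going by these compounds, how far compound 2 truly lies from compound 1 and compound 4 stays open. So does whether a plain phenyl or a 4-chlorophenyl group at this position would give numbers in the same range.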